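Benzothiazolyl thioether anilides: HEK293 cytotoxicity notes

The source may report more compounds than this note shows. Statements on the series, on what has been measured and on what is new or still open speak of the compounds shown alone.

Measured so far:
compound 1 `O=C(Nc1ccc(Sc2nc3ccccc3s2)cc1)c1cc(Br)cc(Br)c1O`, 66000 nM
compound 2 `O=C(Nc1ccc(Sc2nc3ccccc3s2)c(Cl)c1)c1ccccc1O`, 64000 nM

In an ADME assay on HEK293 cells (Homo sapiens) for cytotoxicity, read by reporter gene assay and resazurin assay, with a stated time of 48 h (on this read-out higher numbers stand for lower toxicity in this test and lower numbers for higher toxicity in this test), compound 1 gives 66000 nM. This is the higher of the two numbers, but compound 2 with 64000 nM sits within the scatter, so the two readings are not distinguished. For the measured compounds named here, no step between measured compounds is available.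

Compound 3 `COc1c(Br)cc(Br)cc1C(=O)Nc1ccc(Sc2nc3ccccc3s2)cc1` differs from compound 1 by methyl in place of hydrogen on an oxygen on an aromatic ring. Going by the values given here, with only two near-identical readings in hand, no step beyond the scatter is expected from compound 1 to compound 3 in this assay: the expected step is a 1.1-fold lower number from compound 1 to compound 3 (0.04 log units; within the scatter). Compound 3 is estimated at 60000 nM, with a range from 25000 nM to 150000 nM.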

Compound 3, half-maximal cytotoxic concentration: > 100000 nM
Compound 3: a limit, no number; the forecaster's own chance of this, stated with the estimate: 25%; middle value at least 1.6-fold (0.22 log units) from the limit.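

Replacing hydrogen with methyl on an oxygen on an aromatic ring, hydroxy to methoxy, gives an at least 1.5-fold higher number from compound 1 to compound 3 (0.18 log units; that floor lies within the scatter) in this assay. The hydroxy hydrogen can therefore be capped at this position without any drop in the number, though the floor of the step does not establish a rise. The reading of compound 3 is a limit and not a number, so the full size of the step stays unknown: the limit of > 100000 nM in this assay, at which 1 of the 3 values shown sits.

Open, from the compounds shown here alone, is how a longer chain such as ethoxy, or an amine in place of hydroxy, reads at this position. Also open, going by these compounds, is whether methoxy behaves the same way on the core of compound 2.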